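The compounds below may be only part of what the source reports. "The series", "measured", "known", "first", "only" and "open" are said of these compounds alone.

Measured so far:
- compound 1 `Cn1cncc1CN1CC(N(CC2CCN(C(=O)c3ccc(Cl)cc3)CC2)S(=O)(=O)c2ccccn2)Cc2cc(C#N)ccc21`, 0.5 10^-6 cm/s
- compound 2 `Cc1noc(C)c1CN(C1Cc2cc(C#N)ccc2N(Cc2cncn2C)C1)S(=O)(=O)c1ccccn1`, 8 10^-6 cm/s

Two compounds of the series have numbers in an ADME assay on Caco-2 cells (Homo sapiens) for permeability, in the apical to basolateral direction; a higher number here means that the compound crosses the layer faster, a lower number that the compound crosses the layer more slowly. Compound 1 gives 0.5 10^-6 cm/s, and compound 2 gives 8 10^-6 cm/s. Compound 2 thus stands highest of the two, and its gap to compound 1 lies beyond the scatter of repeated measurements. Among the measured compounds shown here, the two differ in more than one place, so no single step between them is counted; only the two values themselves are on record.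

The next compound, compound 3 `CCOC(=O)N1CCC(CN(C2Cc3cc(C#N)ccc3N(Cc3cncn3C)C2)S(=O)(=O)c2ccccn2)CC1`, follows from compound 2 by one change: 1-(ethoxycarbonyl)piperidin-4-yl in place of 3,5-dimethyl-1,2-oxazol-4-yl on a saturated chain carbon bound to a sulfonamide nitrogen. For the measured compounds named here, no measured pair shows this change on its own, so the size of the step in this assay must be judged from the two values alone. The expectation is that the number moves downward from compound 2 by a step beyond the scatter, but not as far as the value of compound 1, so that a 2.7-fold lower number from compound 2 to compound 3 (0.43 log units; beyond the scatter) is what is estimated. Compound 3 is accordingly expected to give about 3 10^-6 cm/s in this assay, within a range from 1 10^-6 cm/s to 8 10^-6 cm/s.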

Compound 3, apparent permeability: 2.6 10^-6 cm/s
Compound 3: the middle estimate sits 1.2-fold (0.06 log units) above what was measured, within the range that was stated.
By their numbers in this assay, from the lowest: compound 1; then compound 3; then compound 2.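

Notes on the series: in this assay, 1-(ethoxycarbonyl)piperidin-4-yl in place of 3,5-dimethyl-1,2-oxazol-4-yl on a saturated chain carbon bound to a sulfonamide nitrogen gives a 3.1-fold lower number from compound 2 to compound 3 (0.49 log units; beyond the scatter) as the first single-change reading at this position, so the number responds to this swap beyond the scatter. Ethoxy in place of 4-chlorophenyl on a carbonyl carbon gives a 5.2-fold higher number from compound 1 to compound 3 (0.72 log units; beyond the scatter) and shows that the group on that carbonyl carbon also moves the number beyond the scatter, even with the rest of the structure held constant. Compound 3 thereby connects compound 1 and compound 2 through two single-change steps, although no supporting data explain either step.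

Going by these compounds, it remains open how a smaller group on that carbonyl carbon, such as methoxy, or a free secondary amine in place of the whole ethoxycarbonyl group would read in this assay. Also open, on these data alone, is whether a phenyl ring without chlorine on the carbonyl carbon would read with compound 1 or with compound 3, which would separate the contribution of the chlorine from that of the aromatic ring.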